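A few compounds are considered here, and "the series" means these few. Any claim that something is new, unique, unknown or untested is made for them only; others in the source may bear on it.

Compound 1 `COc1cc(C(C)=O)ccc1OCCCN1CCC(CC(c2ccc(F)cc2)c2ccc(F)cc2)CC1`: 3.16 nM in a functional assay (aorta) with Oryctolagus cuniculus as the target; a higher number here means weaker binding, a lower number tighter binding
Compound 2 `COc1cc(C(C)=O)ccc1OCCCCCCN1CCC(C(c2ccc(F)cc2)c2ccc(F)cc2)CC1`: 6.31 nM
Compound 3 `NC(=O)c1ccc(OCCCN2CCC(C(c3ccc(F)cc3)c3ccc(F)cc3)CC2)cc1`: 31.6 nM

Among these three, compound 3 gives the highest number in this assay; compound 2 comes closest to it and compound 1 lies furthest from it, and both gaps are beyond the usual scatter. Compound 4 `Fc1ccc(C(c2ccc(F)cc2)C2CCN(CCCSc3ccccc3)CC2)cc1` differs from compound 3 in one place: phenylsulfanyl in place of 4-carbamoylphenoxy on a saturated chain carbon, three bonds along the chain from an amine nitrogen in a ring. For the measured compounds named here, no pair of measured compounds shows a change of this kind, so the expectation rests on the numbers for compound 3 alone. The step from compound 3 to compound 4 is expected to be small, if anything toward a slightly higher number, and not clearly beyond the scatter: a 1.3-fold higher number from compound 3 to compound 4 (0.10 log units; within the scatter). Compound 4 is therefore estimated at 40 nM, within a range from 10 nM to 160 nM.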

Compound 4, dissociation constant: 3.16 nM
Beside the measured number, compound 4's estimate is 13-fold (1.10 log units) above it, outside the stated range (below it).
By their numbers in this assay, from the lowest: compounds 1, 4 and 2 (each within the scatter of the next); then compound 3.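

In this assay there is a 10-fold lower number from compound 3 to compound 4 (1.00 log units; beyond the scatter) when phenylsulfanyl replaces 4-carbamoylphenoxy on the saturated chain carbon, so this position clearly responds to the group it carries. The entering group has no hydrogen-bond donor, so binding this tight does not depend on one here. No supporting data explain the step. The change swaps the linking atom and removes the carbamoyl together, so the compounds shown cannot separate the two. From the compounds shown here alone, how a plain phenoxy or a carboxylic acid on that ring would read remains open.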